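The source may report more compounds than this note shows. Statements on the series, on what has been measured and on what is new or still open speak of the compounds shown alone.

Within the data shown here, in a functional assay on HepG2 cells (Homo sapiens) for antiproliferative activity, read by MTT assay, with a stated time of 24 h (on this read-out higher numbers stand for weaker inhibition and lower numbers for stronger inhibition), compound 1 (`COc1cccc(CSc2nnc(-c3ccc4c(c3)OCCO4)n2-c2ccccc2)c1`) gives 35100 nM and compound 2 (`Fc1ccc(CSc2nnc(-c3ccc4c(c3)OCCO4)n2-c2ccccc2)cc1`) gives 1020 nM as the lower of the two numbers so far. Compound 3 (`Fc1cccc(F)c1CSc1nnc(-c2ccc3c(c2)OCCO3)n1-c1ccccc1`) has not yet been measured. It departs from compound 2 by a single change (2,6-difluorophenyl in place of 4-fluorophenyl on a saturated chain carbon bound to a sulfur), with 2,6-difluorophenyl in place of 4-fluorophenyl on a saturated chain carbon bound to a sulfur. Among the measured compounds shown here, only one measured step bears on this change. That step (a 34-fold lower number from compound 1 to compound 2 (1.54 log units; beyond the scatter)) is large and beyond the scatter, and it falls at the same place, where 4-fluorophenyl replaced 3-methoxyphenyl. It shows that the number in this assay can move widely with the group at this place. However, it is one pair with a different exchange, and it gives no direction for the new one. For the measured compounds named here, no step clearly beyond the scatter is therefore expected, only a slight lean towards a higher number. The estimated step (a 1.5-fold higher number from compound 2 to compound 3 (0.17 log units; within the scatter)) reflects that lean. Compound 3 is expected at 1500 nM (estimated range 300 nM to 10000 nM) in this assay and the wide range reflects how far the earlier step travelled.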

Compound 3, half-maximal inhibitory concentration: 2070 nM
For compound 3 the middle estimate is 1.4-fold (0.14 log units) below the measured one, within the range that was stated.
By their numbers in this assay, from the lowest: compound 2; then compound 3; then compound 1.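

In this assay the exchange of 4-fluorophenyl for 2,6-difluorophenyl on a saturated chain carbon bound to a sulfur gives a 2.0-fold higher number from compound 2 to compound 3 (0.31 log units; beyond the scatter) and so stays modest, a much smaller move than the earlier exchange at this place. The comparison with the methoxy compound gives a 17-fold lower number from compound 1 to compound 3 (1.23 log units; beyond the scatter) and is large, which shows that a second fluorine-bearing group at this place also lies far under 3-methoxyphenyl on this read-out. Among these three compounds, the two fluorinated groups therefore lie much nearer to each other than either lies to 3-methoxyphenyl, and none of the three goes against this.

Still open, on these data alone, is whether the high number of compound 1 goes with the methoxy group itself, or whether an unsubstituted phenyl, a chlorophenyl, a longer chain or a carboxylic acid at this place would fall with the fluorinated compounds or apart from them. No measurement offered here accounts for the size of either step.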